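From 6-methoxypyridin-3-yl to 4-(trifluoromethyl)phenyl on the amide carbonyl

The compounds below may be only part of what the source reports. "The series", "measured", "known", "first", "only" and "open" are said of these compounds alone.

Three compounds share one core and differ only in the group on the carbonyl carbon. In a functional assay on MDA-MB-231 cells (Homo sapiens) for antiproliferative activity, read by MTT assay, with a stated time of 24 h (a higher number here means a weaker inhibitor, a lower number a stronger inhibitor), compound 1 (`COC(=O)c1scc(-c2ccc(NC(=O)c3ccc4ccccc4c3)cc2)c1OC`) gives 5250 nM with naphthalen-2-yl, compound 2 (`COC(=O)c1scc(-c2ccc(NC(=O)c3ccccn3)cc2)c1OC`) gives 8250 nM with pyridin-2-yl, and compound 3 (`COC(=O)c1scc(-c2ccc(NC(=O)c3ccc(OC)nc3)cc2)c1OC`) gives 15300 nM with 6-methoxypyridin-3-yl. Compound 3 therefore stands level with compound 2 within the scatter, given the step of a 1.9-fold higher number from compound 2 to compound 3 (0.27 log units; within the scatter) and the modest step of a 2.9-fold higher number from compound 1 to compound 3 (0.46 log units; beyond the scatter) places it beyond the scatter on the weaker side of compound 1.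

Compound 4 (`COC(=O)c1scc(-c2ccc(NC(=O)c3ccc(C(F)(F)F)cc3)cc2)c1OC`) has not yet been measured. Its change is 4-(trifluoromethyl)phenyl in place of 6-methoxypyridin-3-yl on a carbonyl carbon with 4-(trifluoromethyl)phenyl in place of 6-methoxypyridin-3-yl on a carbonyl carbon whose other neighbour is an amide-type nitrogen.

Among the measured compounds, only compound 1 resembles compound 4 in carrying an aromatic group of carbon only, and the step of a 2.9-fold higher number from compound 1 to compound 3 (0.46 log units; beyond the scatter) suggests some return towards its number. Compound 2 tempers this, as the step of a 1.6-fold higher number from compound 1 to compound 2 (0.20 log units; within the scatter) stays within the scatter despite its ring nitrogen. Going by the values given here, no measured compound carries a trifluoromethyl group, so the expectation remains loose.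

The expected step is a 1.8-fold lower number from compound 3 to compound 4 (0.26 log units; within the scatter) and it is expected to be small at best. For compound 4 the estimated value in this assay is 8500 nM with an expected range from 3500 nM to 20000 nM around it.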

Compound 4, half-maximal inhibitory concentration: 18300 nM
Beside the measured number, compound 4's estimate is 2.2-fold (0.33 log units) below it; the range from low to high includes it.
By their numbers in this assay, from the lowest: compounds 1, 2, 3 and 4 (each within the scatter of the next, the first and the last beyond it).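

In this assay, the change to 4-(trifluoromethyl)phenyl on the carbonyl carbon gives a 1.2-fold higher number from compound 3 to compound 4 (0.08 log units; within the scatter), so removing the ring nitrogen and the hydrogen-bond acceptors of 6-methoxypyridin-3-yl does not by itself separate these two compounds. The new group does stand apart from two earlier ones, with a 2.2-fold higher number from compound 2 to compound 4 (0.35 log units; beyond the scatter) and a 3.5-fold higher number from compound 1 to compound 4 (0.54 log units; beyond the scatter), both modest steps. Compound 1 and compound 4 both carry aromatic groups of carbon only yet lie at opposite ends of the series, so among these four compounds, having a ring of carbon only does not sort the numbers, and nothing shown bears on why they fall as they do.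

The compounds shown leave open whether the trifluoromethyl group itself matters, which a plain phenyl ring or a phenyl ring carrying a methyl group or a chlorine atom would help to separate from the effect of the ring. From the compounds shown here alone, it also remains open how this position responds to a group that is not an aromatic ring, such as a piperidine ring or a short alkyl chain, or to a phenyl ring bearing an amine or a carboxylic acid.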